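The source may hold more compounds than are shown below. What is called first, only, known or untested is meant among the compounds shown, and "the series" means these compounds.

Three compounds have been measured in a functional assay on A549 cells (Homo sapiens) for cytotoxicity, read by sulforhodamine B assay, with a stated time of 72 h; on this read-out lower numbers stand for stronger inhibition and higher numbers for weaker inhibition:

Compound 1, `Nc1sc(-c2ccc(Cl)cc2)c(-c2ccc(Cl)cc2)c1C(=O)NC1CCCCC1`, gives 2410 nM.
Compound 2, `Nc1sc(-c2ccc(Cl)cc2)c(-c2ccc(Cl)cc2)c1C(=O)N1CCCC1`, gives 890 nM.
Compound 3, `Nc1sc(-c2ccc(Br)cc2)c(-c2ccc(Cl)cc2)c1C(=O)NC1CCCCC1`, gives 9590 nM.

Compound 1 and compound 2 share one core, and compound 2 differs from compound 1 in this way: pyrrolidin-1-yl in place of cyclohexylamino on a carbonyl carbon. That change brought a 2.7-fold lower number from compound 1 to compound 2 (0.43 log units; beyond the scatter) in this assay. Compound 3 carries a different core; the difference from compound 1 is bromo in place of chloro on an aromatic carbon, and it gave a 4.0-fold higher number from compound 1 to compound 3 (0.60 log units; beyond the scatter), leaving compound 3 with the highest number of the three.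

Compound 4, `Nc1sc(-c2ccc(Br)cc2)c(-c2ccc(Cl)cc2)c1C(=O)N1CCCC1`, has not yet been measured in this assay. It stands to compound 3 as compound 2 stands to compound 1: pyrrolidin-1-yl in place of cyclohexylamino on a carbonyl carbon. The place of the change reads the same word for word in both pairs, a carbonyl carbon whose other neighbours are an aromatic carbon, so this is the same change, now made on the core of compound 3.

Going by the values given here, the only guide is the one earlier occurrence. On the core of compound 1, pyrrolidin-1-yl in place of cyclohexylamino gave a modest move to a lower number; nothing shows whether the core of compound 3 answers the same way, since the pairs of compounds differing in the core are few. Compound 4 is therefore expected to show a step of about a 2.7-fold lower number from compound 3 to compound 4 (0.44 log units; beyond the scatter), resting on the step of a 2.7-fold lower number from compound 1 to compound 2 (0.43 log units; beyond the scatter). For compound 4 the estimate in this assay is 3500 nM, with a plausible range from 1400 nM to 8500 nM.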

Compound 4, half-maximal inhibitory concentration: 7460 nM
The estimate for compound 4 lay 2.1-fold (0.33 log units) below the measured number; low and high end bracket the measured number.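

In this assay, going by these compounds alone, the step on the core of compound 3 reads a 1.3-fold lower number from compound 3 to compound 4 (0.11 log units; within the scatter), so on this core pyrrolidin-1-yl in place of cyclohexylamino leaves compound 3 and compound 4 indistinguishable, yet this does not establish that the core alters the effect of the change, since the two occurrences cannot be told apart: the same change on two cores in this assay, a 2.7-fold lower number (0.43 log units; beyond the scatter) from compound 1 to compound 2 and a 1.3-fold lower number (0.11 log units; within the scatter) from compound 3 to compound 4, 2.1-fold (0.32 log units) apart, within the scatter of two such steps Bromo in place of chloro, read on the pyrrolidin-1-yl amides, gives an 8.4-fold higher number from compound 2 to compound 4 (0.92 log units; beyond the scatter), in the same direction as on the cyclohexylamino amides and again without a separable difference between the two occurrences: the same change on two cores in this assay, a 4.0-fold higher number (0.60 log units; beyond the scatter) from compound 1 to compound 3 and an 8.4-fold higher number (0.92 log units; beyond the scatter) from compound 2 to compound 4, 2.1-fold (0.32 log units) apart, within the scatter of two such steps With only two occurrences of each change, the series shows no demonstrated dependence of either change on the core, but it does not show that either one carries over reliably, and a true difference smaller than the scatter of two such steps would go unseen.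

The compounds shown leave open whether other groups on the carbonyl carbon, such as morpholin-4-yl, piperidin-1-yl or an open-chain diethylamino group, would follow the same pattern on these two cores. They also leave open how fluoro, methyl or methoxy in place of the bromo or chloro would behave.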